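The source may report more compounds than this note shows. Statements on the series, on what has been measured and on what is new or still open speak of the compounds shown alone.

Compound 3 `N=c1c2c(-c3ccccc3)c(-c3ccccc3)n(CC3CCCCC3)c2ncn1C1CCOCC1` has no reported result in an ADME assay for permeability, using PAMPA, with a stated time of 30 min, at pH 7.4 (on this read-out higher numbers stand for higher permeability and lower numbers for lower permeability), where its entry reads "nd" (no result reported). Compound 1 `COc1ccc(Cn2c(-c3ccccc3)c(-c3ccccc3)c3c(=N)n(C4CCOCC4)cnc32)cc1` likewise has no number, with its entry reading "nd" (no result reported). Compound 2 `N=c1c2c(-c3ccccc3)c(-c3ccccc3)n(CC3CC3)c2ncn1CC1CCOCC1` gives only a limit of the assay, > 1000 10^-6 cm/s, which is the limit described at the limit of > 1000 10^-6 cm/s in this assay, at which 1 of the 3 values shown sits. So compound 3 stands nowhere on a numerical scale: of the three entries in this assay, one is a limit and two have no value. Compound 4 `N=c1c2c(-c3ccccc3)c(-c3ccccc3)n(CC3CC3)c2ncn1C1CCOCC1` differs from compound 3 by cyclopropyl in place of cyclohexyl on a saturated chain carbon bound to an aromatic nitrogen. Among the measured compounds shown here, with no measured step between any two compounds, no size or direction can be stated for this change. Compound 4 is expected to give about 900 10^-6 cm/s, with a range from 350 10^-6 cm/s to 1500 10^-6 cm/s, and its result may itself come back only as a limit.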

Compound 4, apparent permeability: > 1000 10^-6 cm/s
Compound 4: a limit, no number; the forecaster's own chance of this, stated with the estimate: 45%; middle value at least 1.1-fold (0.04 log units) from the limit.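

In this assay, among the compounds shown here, compound 2 and compound 4 both give only a limit of the assay, so no step between them can be read. The compounds shown leave open how far past that limit each one lies.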